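A few compounds are considered here, and "the series" means these few. Any claim that something is new, unique, unknown or untested is made for them only; others in the source may bear on it.

Measured compounds:
- compound 1, `O=C(C=CNc1cc(-c2ccccc2)nn1-c1ccccc1)c1cccs1`, 2420 nM
- compound 2, `COc1ccc(-c2nc3c(c(-c4ccccc4)nn3-c3ccccc3)c(-c3ccc(N4CCCCC4)cc3)c2C#N)cc1`, 12500 nM
- compound 3, `Cc1ccc(-c2ccnc3c2c(-c2ccccc2)nn3-c2ccccc2)cc1`, 10700 nM

In a functional assay on HepG2 cells (Homo sapiens) for inhibition, read by MTT assay, with a stated time of 48 h (on this read-out higher numbers stand for weaker inhibition and lower numbers for stronger inhibition), compound 1 gives the lowest number of the three, and both compound 3 and compound 2 stand above it by more than the scatter, so compound 1 is the strongest inhibitor of the measured set. Compound 2 and compound 3 differ from compound 1 in many places at once, so no single change can be read from their values.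

Compound 4, `COc1ccc(C(=O)C=CNc2cc(-c3ccccc3)nn2-c2ccccc2)cc1`, differs from compound 1 in one place: 4-methoxyphenyl in place of thiophen-2-yl on a carbonyl carbon. Within the data shown here, no pair of measured compounds shares this change, so there is no measured step to lean on. One aromatic ring bearing a single hydrogen-bond acceptor replaces another of the same kind on the carbonyl carbon, and the rest of compound 1 is kept. The step from compound 1 to compound 4 is therefore expected to be small, within or close to the scatter, with no clear direction. Compound 4 is estimated at 2600 nM, with a range from 900 nM to 7500 nM, which corresponds to an expected step of a 1.1-fold higher number from compound 1 to compound 4 (0.03 log units; within the scatter).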

Compound 4, half-maximal inhibitory concentration: 2030 nM
Compound 4: the middle estimate sits 1.3-fold (0.11 log units) above what was measured; low and high end bracket the measured number.
By their numbers in this assay, from the lowest: compounds 4 and 1 (each within the scatter of the next); then compounds 3 and 2 (each within the scatter of the next).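

In this assay, among these compounds, 4-methoxyphenyl in place of thiophen-2-yl on a carbonyl carbon gives a 1.2-fold lower number from compound 1 to compound 4 (0.08 log units; within the scatter), the first step that can be read in this set. At this place, a five-membered aromatic ring with a hetero atom and a six-membered aromatic ring of carbon only, the latter carrying a methoxy group, therefore give values within the scatter of each other. Nothing measured bears on what lies behind this result.

Only these two aromatic groups are shown on the carbonyl carbon, so it stays open whether a cyclohexyl group, or a phenyl ring carrying a carboxylic acid or a dimethylamino group, would read the same. From the compounds shown here alone, compound 2 and compound 3 differ from compound 1 in many places at once, and what the chain shared by compound 1 and compound 4 contributes also stays open.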